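The source may report more compounds than this note shows. Statements on the series, on what has been measured and on what is new or still open speak of the compounds shown alone.

In an in vitro ADME assay on microsomes from liver (Mus musculus) for pharmacokinetics, read by LC-MS, with a stated time of 10 min, tested at 1 uM (on this read-out higher numbers stand for fast clearance and lower numbers for slow clearance), compound 1 `Cc1ccc(NC(=O)[C@H]2CN(C)C[C@@H]2c2ccc(/C=C/C(=O)Nc3ccccc3N)cc2)cc1` gives 62 mL/min/kg while compound 2 `CN1C[C@H](C(=O)Nc2ccc(F)c(F)c2)[C@@H](c2ccc(/C=C/C(=O)Nc3ccccc3N)cc2)C1` gives 46 mL/min/kg and compound 3 `Cc1cc(NC(=O)[C@H]2CN(C)C[C@@H]2c2ccc(/C=C/C(=O)Nc3ccccc3N)cc2)ccc1F` gives 62 mL/min/kg on the same scale. Compound 3 thus stands level with compound 1 and within the scatter of compound 2. Compound 4 `CN1C[C@H](C(=O)Nc2ccc(F)cc2F)[C@@H](c2ccc(/C=C/C(=O)Nc3ccccc3N)cc2)C1` differs from compound 3 by 2,4-difluorophenyl in place of 4-fluoro-3-methylphenyl on an amide-type nitrogen with 2,4-difluorophenyl in place of 4-fluoro-3-methylphenyl on an amide-type nitrogen. The measured steps bearing on this are a 1.3-fold higher number from compound 2 to compound 3 (0.13 log units; within the scatter) when methyl replaces fluoro on an aromatic carbon, then a 1.3-fold lower number from compound 1 to compound 2 (0.13 log units; within the scatter) with 3,4-difluorophenyl entering and no change at the digits printed from compound 1 to compound 3 (within the scatter) with 4-fluoro-3-methylphenyl entering, each within the scatter. Among the measured compounds shown here, no step beyond the scatter is therefore expected, though compound 2 at 46 mL/min/kg as the only measured difluorophenyl compound suggests a slight lean downward. The expected step is a 1.2-fold lower number from compound 3 to compound 4 (0.09 log units; within the scatter) and stays within the scatter. For compound 4 the estimated clearance is 50 mL/min/kg with an expected range from 29 mL/min/kg to 82 mL/min/kg as its bounds.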

Compound 4, clearance: 27 mL/min/kg
Beside the measured number, compound 4's estimate is 1.9-fold (0.27 log units) above it; measured number below the stated range.
By their numbers in this assay, from the lowest: compounds 4, 2, 1 and 3 (each within the scatter of the next, the first and the last beyond it).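

In this assay, the group on the amide-type nitrogen now makes a difference beyond the scatter, with a 2.3-fold lower number from compound 3 to compound 4 (0.36 log units; beyond the scatter) and a 2.3-fold lower number from compound 1 to compound 4 (0.36 log units; beyond the scatter), whereas all steps among compound 1, compound 2 and compound 3 stayed within it. The two difluorophenyl groups are not separated, since a 1.7-fold lower number from compound 2 to compound 4 (0.23 log units; within the scatter), so the change from 3,4-difluorophenyl to 2,4-difluorophenyl alone shows no clear effect. No evidence on the cause of these steps is available.

From the compounds shown here alone, whether a nitrile, a methoxy group or a carboxylic acid on this phenyl ring would give a similar clearance remains open.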